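This account rests on a few compounds, and the source may have more. Where it says the series, first, only, none or still open, it means among the compounds named here.

Among the compounds with values here, compound 2 `COC(=O)c1ccc(-c2c(C#N)[n+]([O-])c3cc(C)ccc3[n+]2[O-])cc1` is one of two compounds so far examined in an ADME assay on Vero cells (Chlorocebus sabaeus) for cytotoxicity, read by MTT assay, with a stated time of 72 h; a lower number here means a stronger inhibitor, a higher number a weaker inhibitor. In this assay compound 2 gives 3.2 ug/mL, the higher of the two numbers, while compound 1 `COc1ccc2c(c1)[n+]([O-])c(C#N)c(-c1ccc(Cl)cc1)[n+]2[O-]` gives 1 ug/mL, a gap beyond the usual scatter. Compound 3 `COC(=O)c1ccc(-c2c(C#N)[n+]([O-])c3cc(OC)ccc3[n+]2[O-])cc1` is not yet measured. It differs from compound 2 in one place: methoxy in place of methyl on an aromatic carbon. Within the data shown here, no measured pair shows this change alone, so the expected step from compound 2 to compound 3 is small and downward, a 1.6-fold lower number from compound 2 to compound 3 (0.20 log units; within the scatter), because compound 1, which also carries a methoxy on its core, gives 1 ug/mL. Compound 3 is therefore expected to give 2 ug/mL, estimated between 0.8 ug/mL and 5 ug/mL.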

Compound 3, half-maximal inhibitory concentration: 3.9 ug/mL
Compound 3: middle estimate off by 2.0-fold (0.29 log units), on the low side, and the stated range covers the measured number.
By their numbers in this assay, from the lowest: compound 1; then compounds 2 and 3 (each within the scatter of the next).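

In this assay, methoxy in place of methyl on an aromatic carbon of the shared core gives a 1.2-fold higher number from compound 2 to compound 3 (0.09 log units; within the scatter), so this change at this position does not separate compound 2 from compound 3. With methoxy on the core of both, methoxycarbonyl in place of chloro on an aromatic carbon gives a 3.9-fold higher number from compound 1 to compound 3 (0.59 log units; beyond the scatter), a step beyond the scatter that points to the other ring, not the methoxy. Nothing available explains either step. Still open, from the compounds shown here alone, is whether an amine or a longer alkoxy chain at the methyl position, or a carboxylic acid in place of the methoxycarbonyl, would shift the number.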